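Swapping carboxy for amino on compound 3

The source may hold more compounds than are shown below. What is called first, only, known or untested is meant among the compounds shown, and "the series" means these compounds.

- Compound 1 `Nc1ccc(S(=O)(=O)Nc2cccc3cc[nH]c23)cc1`: 6.1 ug/mL
- Compound 2 `N#Cc1ccc(S(=O)(=O)Nc2cccc3c(C#N)c[nH]c23)cc1`: 0.12 ug/mL
- Compound 3 `N#Cc1c[nH]c2c(NS(=O)(=O)c3ccc(C(=O)O)cc3)cccc12`: > 100 ug/mL (a limit, not a number)

In a functional assay on MC-38 cells (Mus musculus) for antiproliferative activity (on this read-out higher numbers stand for weaker inhibition and lower numbers for stronger inhibition), compound 3 stands at the limit of > 100 ug/mL in this assay, at which 1 of the 3 values shown sits. Compound 4 `N#Cc1c[nH]c2c(NS(=O)(=O)c3ccc(N)cc3)cccc12` differs from it in one place: amino in place of carboxy on an aromatic carbon. Within the data shown here, one measured step bears on this place: an at least 830-fold higher number from compound 2 to compound 3 (2.92 log units; beyond the scatter), a large rise when carboxy replaced cyano. Compound 4 loses that same carboxy, so a large step towards a lower number, meaning stronger inhibition, is expected. Compound 1 also carries amino there, lacks the core cyano, and gives 6.1 ug/mL. Compound 2, with cyano there and on the core, gives 0.12 ug/mL. The expected change is an at least 100-fold lower number from compound 3 to compound 4 (2.00 log units; beyond the scatter). Compound 4 is estimated at 1 ug/mL, with an expected range from 0.15 ug/mL to 8 ug/mL.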

Compound 4, half-maximal inhibitory concentration: 0.28 ug/mL
Estimate against measurement, compound 4: 3.6-fold (0.55 log units) above, within the range that was stated.
By their numbers in this assay, from the lowest: compound 2; then compound 4; then compound 1. At a limit, above all of these: compound 3.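

In this assay compound 3 gives a limit and not a number: the limit of > 100 ug/mL in this assay, at which 1 of the 4 values shown sits. Even so, amino in place of carboxy on this aromatic carbon brings a large gain in inhibition (an at least 350-fold lower number from compound 3 to compound 4 (2.55 log units; beyond the scatter)), and amino falls only modestly short of cyano at the same place (a 2.3-fold higher number from compound 2 to compound 4 (0.37 log units; beyond the scatter)). With amino held fixed, the cyano on the core also shows its own large effect (a 22-fold lower number from compound 1 to compound 4 (1.34 log units; beyond the scatter)). The compounds shown leave open how a methoxy or dimethylamino group would fare at this place. They also leave open whether a carboxamide could stand in for the cyano on the core.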